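Lengthening the Chain: From Compound 3 to Compound 4

A few compounds are considered here, and "the series" means these few. Any claim that something is new, unique, unknown or untested is made for them only; others in the source may bear on it.

Compound 1 `CCCCc1ccc(-c2c(CC)[nH]c(=O)n2C)cc1`: 13900 nM
Compound 2 `Cc1[nH]c(=O)n(C)c1-c1ccc(CC(C)C)cc1`: 7800 nM
Compound 3 `Cc1[nH]c(=O)n(C2CCCCC2)c1-c1ccc(CC(C)C)cc1`: 10900 nM

All three were tested in a functional assay on brain (Rattus norvegicus, strain Wistar) for inhibition; on this read-out higher numbers stand for weaker inhibition and lower numbers for stronger inhibition. Compound 3 stands second highest of the three numbers, but its distance to compound 1 and to compound 2 lies within the scatter in both cases, so on these figures the three cannot be told apart. Within the data shown here, the only step between compounds that differ in a single place, a 1.4-fold higher number from compound 2 to compound 3 (0.15 log units; within the scatter), put cyclohexyl in place of methyl on an aromatic nitrogen and stayed within the scatter.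

Compound 4 `CCCCCCCCc1ccc(-c2c(C)[nH]c(=O)n2C2CCCCC2)cc1` has not yet been measured. It differs from compound 3 by heptyl in place of isopropyl on a saturated chain carbon bound to an aromatic carbon. Among the measured compounds shown here, no measured step touches that position on its own: compound 1 and compound 2 differ there but also elsewhere, and in this assay compound 1 gives 13900 nM while compound 2 gives 7800 nM, two values within the scatter of each other. With nothing pointing either way, the step of a 1.1-fold lower number from compound 3 to compound 4 (0.04 log units; within the scatter) is expected to fall within the scatter. Compound 4 is estimated at 10000 nM, with a range from 3000 nM to 35000 nM.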

Compound 4, half-maximal inhibitory concentration: 10300 nM
Beside the measured number, compound 4's estimate is 1.0-fold (0.01 log units) below it; low and high end bracket the measured number.
By their numbers in this assay, from the lowest: compounds 2, 4, 3 and 1 (each within the scatter of the next).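

In this assay, among these compounds, putting heptyl in place of isopropyl on a saturated chain carbon bound to an aromatic carbon gives a 1.1-fold lower number from compound 3 to compound 4 (0.02 log units; within the scatter), and this is the first step to touch this position on its own. Isopropyl has 3 heavy atoms and heptyl has 7, so this position accepts the larger chain, and the two compounds still cannot be told apart on this read-out; the same difference, cut one bond further out, reads isobutyl to octyl. Nothing available explains this result or says what the chain does at this position.

This is a single pair, and both chains are made only of carbon, with no hydrogen-bond donors or acceptors, so the compounds shown leave open whether a chain ending in an amine or a carboxylic acid, or a longer chain such as dodecyl, would move the number beyond the scatter. They also leave open whether the same swap would read alike with methyl rather than cyclohexyl on the aromatic nitrogen.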